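The compounds below may be only part of what the source reports. "The series", "measured", "known", "first", "only" and "open" are said of these compounds alone.

Measured so far:
compound 1 `O=C(OC1(C(=O)Nc2ccc([N+](=O)[O-])cc2)CCCCC1)c1ccc(Br)cc1` — 284 nM
compound 2 `O=C(OC1(C(=O)Nc2ccc([N+](=O)[O-])cc2)CCCCC1)c1ccc([N+](=O)[O-])cc1` — 14.1 nM
compound 3 `CCC(=O)OC1(C(=O)Nc2ccc([N+](=O)[O-])cc2)CCCCC1` — 21.5 nM

In a functional assay on HepG2 cells (Homo sapiens) for inhibition, read by MTT assay, with a stated time of 72 h (a lower number here means a stronger inhibitor, a higher number a weaker inhibitor), compound 3 stands second highest of the three numbers; its nearest neighbour is compound 2, with a 1.5-fold higher number from compound 2 to compound 3 (0.18 log units; within the scatter) lying within the scatter, and its furthest is compound 1, with a 13-fold lower number from compound 1 to compound 3 (1.12 log units; beyond the scatter) lying beyond it. Between the two aryl esters themselves, a 20-fold lower number from compound 1 to compound 2 (1.30 log units; beyond the scatter) is large.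

Compound 4 `CC(=O)Oc1ccccc1C(=O)OC1(C(=O)Nc2ccc([N+](=O)[O-])cc2)CCCCC1` is not yet measured. Its change from compound 3 is 2-acetoxyphenyl in place of ethyl on a carbonyl carbon. Both steps at the same carbonyl carbon bear on this: a 13-fold lower number from compound 1 to compound 3 (1.12 log units; beyond the scatter) shows one aryl ester far weaker than the ethyl ester, while a 1.5-fold higher number from compound 2 to compound 3 (0.18 log units; within the scatter) shows another aryl ester equal to it within the scatter. The two aryl esters differ only in the substituent on the ring, and the 2-acetoxyphenyl group matches neither of them, so the direction is open: anything from no step beyond the scatter to a sizeable rise in the number is consistent with the data. An intermediate outcome is taken as the estimate. Compound 4 is therefore expected at 60 nM in this assay, with a range of 12 nM to 300 nM, which means an expected step of a 2.8-fold higher number from compound 3 to compound 4 (0.45 log units; beyond the scatter).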

Compound 4, half-maximal inhibitory concentration: 17.7 nM
Compound 4: the middle estimate sits 3.4-fold (0.53 log units) above what was measured; measured number inside the range.
By their numbers in this assay, from the lowest: compounds 2, 4 and 3 (each within the scatter of the next); then compound 1.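

In this assay, exchanging the ethyl of two carbons for the 2-acetoxyphenyl group on this carbonyl carbon gives a 1.2-fold lower number from compound 3 to compound 4 (0.08 log units; within the scatter) and so no change beyond the scatter. The same holds against the 4-nitrophenyl ester, with a 1.3-fold higher number from compound 2 to compound 4 (0.10 log units; within the scatter) as the step, whereas a 16-fold lower number from compound 1 to compound 4 (1.21 log units; beyond the scatter) is a large step from the 4-bromophenyl ester, so a second aryl ester now matches the ethyl ester and compound 1 alone stands apart as the weakest of the four. An aromatic ring on this carbonyl carbon is therefore compatible with a low number in compound 2 and compound 4, compound 1 being the one that goes against this, and the data give no measured reason for either result.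

The compounds shown leave open whether the weakness of compound 1 belongs to bromo specifically or would recur with chloro or methyl on the ring. They also leave open how far this carbonyl carbon tolerates other groups, such as a longer alkyl chain, an amine-bearing chain or a carboxylic acid.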